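The source may report more compounds than this note shows. Statements on the series, on what has been measured and on what is new or still open speak of the compounds shown alone.

Measured compounds:
- compound 1, `CCOc1ccccc1-c1ccc(-c2nc3cnccc3c(NC(C)C(=O)O)c2C#N)cc1`: 2.1
- compound 2, `CC[C@@H](Nc1c(C#N)c(-c2ccc(-c3ncccc3C)cc2)nc2cnccc12)C(N)=O`: 2
- compound 3, `CCOc1ccccc1-c1ccc(-c2nc3cnccc3c(NC(CC)CNS(=O)(=O)C3CC3)c2C#N)cc1`: 3.6

The three compounds share one core and were examined in a physicochemical assay for lipophilicity, read by HPLC, at pH 7.5; a higher number here means a more lipophilic compound, a lower number a more polar compound. For the measured compounds named here, compound 1 gives 2.1 there, compound 3 gives 3.6, and the one step between them, a number 1.50 log units higher from compound 1 to compound 3 (beyond the scatter), is the only measured step in the set. Compound 2 stands at the low end of the three numbers with 2; its nearest neighbour is compound 1, within the scatter, while compound 3 lies well beyond it.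

The account now turns to compound 4, `CC[C@@H](Nc1c(C#N)c(-c2ccc(-c3cccc(OC)c3)cc2)nc2cnccc12)C(N)=O`, which is still to be measured in this assay. It differs from compound 2 in one place only: 3-methoxyphenyl in place of 3-methylpyridin-2-yl on an aromatic carbon

Going by the values given here, no measured step touches this place. Among the compounds with values here, the step from compound 1 to compound 3 changed a different part of the molecule, the group on the ring nitrogen, and so cannot be read across directly; it shows only that a single exchange can move the number a long way. Compound 2 therefore has to serve as the anchor on its own. With the pyridine ring giving way to a carbon-only ring bearing a methoxy group, the expected direction is upward. The step expected from compound 2 to compound 4 is a number 0.70 log units higher from compound 2 to compound 4 (beyond the scatter). Compound 4 is accordingly estimated at 2.7, with a range from 2.2 to 3.3.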

Compound 4, distribution coefficient: 2.7
For compound 4 middle estimate and measured number coincide at the digits printed; low and high end bracket the measured number.
By their numbers in this assay, from the lowest: compounds 2 and 1 (each within the scatter of the next); then compound 4; then compound 3.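

In this assay this position now has a measured step of its own: 3-methoxyphenyl in place of 3-methylpyridin-2-yl, on an aromatic carbon and para to a large group, gives a number 0.70 log units higher from compound 2 to compound 4 (beyond the scatter) and so moves the number beyond the scatter. For the compounds shown here, the earlier step, a number 1.50 log units higher from compound 1 to compound 3 (beyond the scatter) and printed as large, lay in the group on the nitrogen, so this modest step is the first sign that the number also answers to a change at the far aryl group while that side chain stays the same. The exchange alters several things at once, with the ring's single hetero atom gone, an oxygen brought in and the heavy-atom count going from 7 to 8, and nothing shown here gives a measured reason for the step.

The compounds shown leave open how the step divides between the loss of the ring nitrogen and the change from methyl to methoxy, a division that a plain phenyl or a 3-methylphenyl group at this place would bear on. Also open, on these data alone, are whether the step holds with the side chains of compound 1 and compound 3, and how an amine or a carboxylic acid on this ring would shift the number.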